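Replacing the 4-fluorophenyl group of compound 3

A few compounds are considered here, and "the series" means these few. Any claim that something is new, unique, unknown or untested is made for them only; others in the source may bear on it.

In an ADME assay on MT4 cells (Homo sapiens) for cytotoxicity, read by MTT assay, with a stated time of 5 days (a lower number here means that less compound is tolerated, a higher number that more compound is tolerated), compound 3 `Cc1cc(OCC(=O)Nc2ccc(F)cc2)nc(Nc2ccc(C#N)cc2)n1` gives > 331000 nM, which is a limit and not a number. Compound 1 `N#Cc1ccc(Nc2nccc(OCC(=O)Nc3ccc(F)cc3)n2)cc1` also gives only a limit, > 344000 nM. Compound 2 `N#Cc1ccc(Nc2nccc(OCC(=O)Nc3cccc(Cl)c3)n2)cc1` likewise gives only a limit, > 329000 nM. Compound 3 therefore has no measured number to stand on, and neither do the other two compounds.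

Compound 4 `Cc1cc(OCC(=O)Nc2ccc(C#N)cc2F)nc(Nc2ccc(C#N)cc2)n1` carries 4-cyano-2-fluorophenyl in place of 4-fluorophenyl on an amide-type nitrogen. The entering group thus brings a triple bond outside aromatic rings and a hydrogen-bond acceptor.

The closest measured precedent is the exchange of 4-fluorophenyl for 3-chlorophenyl at the same kind of nitrogen, a step that the two limits leave unreadable from compound 1 to compound 2. Methyl in place of hydrogen on an aromatic carbon gives a step that the two limits leave unreadable from compound 1 to compound 3, and this is the difference that separates the cores of the two fluorophenyl compounds. Neither step has a readable size, so neither sets a direction or a magnitude for the new exchange.

Only a modest move toward less tolerated compound is expected, as a cautious allowance for an untested group, and the expected at least 1.4-fold lower number from compound 3 to compound 4 (0.15 log units; that floor lies within the scatter) is tentative. Compound 4 is estimated at 230000 nM, with an expected range from 40000 nM to 330000 nM, and it may again be reported only as a limit.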

Compound 4, half-maximal cytotoxic concentration: > 310000 nM
Compound 4: no number, only a limit; the forecaster's own chance of this, stated with the estimate: 60%; at least 1.3-fold (0.12 log units) between middle value and limit.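

Compound 3 and compound 4 are both reported only as limits and not as numbers, so the step from one to the other cannot be read. The compounds shown leave open at what concentration any of them becomes cytotoxic, and whether the exchange of 4-fluorophenyl for 4-cyano-2-fluorophenyl changes that concentration at all.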